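Capping the Alcohol of Compound 2 with an Acetyl

The compounds below may be only part of what the source reports. "The series", "measured", "known", "first", "only" and "open" are said of these compounds alone.

Compound 2 `CC(=O)N1CCN(S(=O)(=O)c2ccc(F)cc2)C(CO)C1` carries a hydroxymethyl on its saturated ring. In an ADME assay on a cell-free system (plasma, Rattus norvegicus, strain Sprague-Dawley) for metabolic stability, read by LC-MS, tested at 1 uM (on this read-out higher numbers stand for a longer-lived compound and lower numbers for a shorter-lived compound), compound 2 gives >= 4 h, which is a limit of the assay rather than a number. Its parent, compound 1 `CC(=O)N1CCN(S(=O)(=O)c2ccc(F)cc2)CC1`, gives >= 4 h in this assay, again a limit; this is the limit of >= 4 h in this assay, at which 2 of the 3 values shown sit. Compound 3 `CC(=O)OCC1CN(S(=O)(=O)c2ccc(F)cc2)CCN1C(C)=O`, which carries an acetoxymethyl on the ring, gives 0.5 h in this assay.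

Compound 4 `CC(=O)OCC1CN(C(C)=O)CCN1S(=O)(=O)c1ccc(F)cc1` arises from compound 2 by acetyl in place of hydrogen on an oxygen on a saturated carbon. Among the measured compounds shown here, of the measured steps, the one from compound 1 to compound 2 is a step that the two limits leave unreadable from compound 1 to compound 2, so it says nothing about size; the one from compound 1 to compound 3 is an at least 8.0-fold lower number from compound 1 to compound 3 (0.90 log units; beyond the scatter). Since compound 4 and compound 3 both carry an acetoxymethyl, a drop of similar size is expected here: an at least 6.6-fold lower number from compound 2 to compound 4 (0.82 log units; beyond the scatter). Compound 4 is therefore estimated to give 0.6 h in this assay, within a range from 0.2 h to 2 h.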

Compound 4, half-life: 0.483 h
Beside the measured number, compound 4's estimate is 1.2-fold (0.09 log units) above it; measured number inside the range.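

In this assay, among the compounds shown here, capping the free hydroxy with an acetyl, with nothing else changed, gives an at least 8.2-fold lower number from compound 2 to compound 4 (0.91 log units; beyond the scatter) as the first readable step at this oxygen. The whole change from the unsubstituted parent, hydrogen to acetoxymethyl on the ring carbon, gives an at least 8.2-fold lower number from compound 1 to compound 4 (0.91 log units; beyond the scatter) as well. The short half-life therefore comes with the acetyl on the oxygen, while the hydroxymethyl with its free hydroxy shows no such fall in these compounds.

As far as these compounds go, how far each fall really reaches stays unknown, since both steps start from a limit of the assay: the limit of >= 4 h in this assay, at which 2 of the 4 values shown sit. Also open, from the compounds shown here alone, is whether a longer chain such as propanoyl in place of the acetyl on that oxygen, or an amine in place of the hydroxy, would behave in the same way.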